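Formyl in place of trifluoromethyl on the shared core

A few compounds are considered here, and "the series" means these few. Any claim that something is new, unique, unknown or untested is made for them only; others in the source may bear on it.

Three compounds sharing a six-carbon chain ending in a phenyl group, joined through a carbonyl to a small aromatic ring, have been measured in an assay on HEK-293T cells for inhibition of diacylglycerol lipase-alpha (Homo sapiens), read by colorimetric assay; on this read-out lower numbers stand for stronger inhibition and higher numbers for weaker inhibition. Compound 1 `Cn1nnc(C(=O)CCCCCCc2ccccc2)n1` gives only a limit of the assay, > 10000 nM. Compound 2 `O=C(CCCCCCc1ccccc1)c1nc(C(=O)C(F)(F)F)co1` gives 123 nM in this assay. Compound 3 `O=C(CCCCCCc1ccccc1)c1nc(C(F)(F)F)co1` gives 214 nM in this assay; the step of a 1.7-fold higher number from compound 2 to compound 3 (0.24 log units; within the scatter) is small. Compound 3 thus holds the highest of the two numbers shown, with compound 2 nearest and within the scatter, while compound 1 sits at a limit (the limit of > 10000 nM in this assay, at which 1 of the 3 values shown sits).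

The next compound, compound 4 `O=Cc1coc(C(=O)CCCCCCc2ccccc2)n1`, differs from compound 3 by formyl in place of trifluoromethyl on an aromatic carbon. Going by the values given here, the only measured step that bears on this change is the one from compound 2 to compound 3, where a carbonyl-bearing group gave way to trifluoromethyl on the same ring carbon and the number moved within the scatter. Compound 4 restores a carbonyl-bearing group, this time a formyl, so he expects the step of a 1.4-fold lower number from compound 3 to compound 4 (0.15 log units; within the scatter) to be small and, if anything, towards a lower number. He estimates that compound 4 gives 150 nM in this assay, with a range from 50 nM to 500 nM.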

Compound 4, half-maximal inhibitory concentration: 1510 nM
The estimate for compound 4 lay 10-fold (1.00 log units) below the measured number; the measured number lies above the stated range.
By their numbers in this assay, from the lowest: compounds 2 and 3 (each within the scatter of the next); then compound 4. At a limit, above all of these: compound 1.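

The earlier compounds shown here left the impression that the group on this aromatic carbon, next to the ring nitrogen, could be exchanged with little consequence, but the formyl group shows that the position is sensitive to what it carries, with a 7.1-fold higher number from compound 3 to compound 4 (0.85 log units; beyond the scatter). A carbonyl at this place is not enough in itself, since removing the trifluoromethyl from the carbonyl carbon of the side group gives a 12-fold higher number from compound 2 to compound 4 (1.09 log units; beyond the scatter), even though compounds 2 and 3, with quite different groups here, lie within the scatter of each other. The step of an at least 6.6-fold lower number from compound 1 to compound 4 (0.82 log units; beyond the scatter) rests on a limit of the assay for compound 1, so it gives only a bound, and compound 4 stays on the measured side of that limit.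

Nothing measured among these compounds accounts for the rise in the number on going to formyl. As far as these compounds go, whether a carboxylic acid, a methyl ester, an amide or a nitrile on this ring carbon would stay close to compound 3 or move towards compound 4 remains open, as does whether a longer chain would shift these numbers in the same way.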